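Fluoro-to-hydrogen step on the amidine-bearing ring

A few compounds are considered here, and "the series" means these few. Any claim that something is new, unique, unknown or untested is made for them only; others in the source may bear on it.

Of the compounds shown here, three have been measured in a functional assay on A549 cells (Homo sapiens) for inhibition, read by sulforhodamine B assay, with a stated time of 48 h; a lower number here means a stronger inhibitor of growth, a higher number a weaker inhibitor of growth. Compound 1 `COc1cc(OC)cc(-c2ccc(-c3ccc(C(=N)N)c(F)c3)s2)c1` gives 400 nM in this assay. Compound 2 `N=C(N)c1ccc(-c2ccc(-c3ccc(Cl)cc3)s2)cc1F` gives 217 nM in this assay, and compound 3 `N=C(N)c1ccc(-c2ccc(-c3ccc(Cl)cc3)s2)cc1` gives 202 nM in this assay. The values of compound 1, compound 2 and compound 3 all lie within the scatter of one another, so no order among them is claimed.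

Compound 2 and compound 3 differ in one place: hydrogen in place of fluoro on an aromatic carbon This change gives a 1.1-fold lower number from compound 2 to compound 3 (0.03 log units; within the scatter) in this assay, a step that stays within the scatter.

Compound 4 `COc1cc(OC)cc(-c2ccc(-c3ccc(C(=N)N)cc3)s2)c1` has not yet been measured in this assay. It stands to compound 1 as compound 3 stands to compound 2: hydrogen in place of fluoro on an aromatic carbon The place is described in the same words for both pairs, so the change is taken as the same one, made here on the core of compound 1. How the core of compound 1 differs from that of compound 2 is not broken down here.

Within the data shown here, for compound 4 the expectation rests on the only matched pair at hand, since from compound 2 to compound 3 the step was a 1.1-fold lower number from compound 2 to compound 3 (0.03 log units; within the scatter) and sat within the scatter. A step of similar size, a 1.1-fold lower number from compound 1 to compound 4 (0.05 log units; within the scatter), is expected from compound 1 to compound 4 in this assay. Compound 4 is therefore estimated at 360 nM in this assay, with a likely range of 200 nM to 650 nM.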

Compound 4, concentration for 50% growth inhibition: 2580 nM
Beside the measured number, compound 4's estimate is 7.2-fold (0.86 log units) below it; the whole stated range lies below it.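

The fluoro-to-hydrogen change does not carry over unchanged between these two cores in this assay: the same change on two cores in this assay, a 1.1-fold lower number (0.03 log units; within the scatter) from compound 2 to compound 3 and a 6.5-fold higher number (0.81 log units; beyond the scatter) from compound 1 to compound 4, 6.9-fold (0.84 log units) apart, beyond the scatter of two such steps

On the core of compound 1, the change gives a 6.5-fold higher number from compound 1 to compound 4 (0.81 log units; beyond the scatter), so fluoro cannot be treated there as a group that can be exchanged for hydrogen without consequence, even though the same exchange on the core of compound 2 stays within the scatter. With only one matched pair on each core, the result shows that the size of this step depends on the core among the compounds shown, but it does not identify which feature of the cores separates the two steps, and it gives no rule for a third core.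

Open, going by these compounds, is whether another group on the same aromatic carbon of the core of compound 1, such as chloro, methyl or methoxy, would keep the number near that of compound 1 or move it toward that of compound 4. Also open, on these data alone, is how the fluoro-to-hydrogen step behaves on further cores, for example with a bromo or a methyl group in place of the chloro of compound 2.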